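This account rests on a few compounds, and the source may have more. Where it says the series, first, only, none or still open, it means among the compounds named here.

Measured so far in a functional assay (spleen, spleen) for activation, with Mus musculus as the target; on this read-out lower numbers stand for an effect already at smaller amounts and higher numbers for an effect only at larger amounts of compound:
compound 1 `Cc1nc(N)c2nc(O)n(Cc3ccccc3)c2n1` gives 1 uM
compound 2 `CCCC[S+]([O-])c1nc(N)c2nc(O)n(Cc3ccccc3)c2n1` gives 0.01 uM

For the measured compounds named here, compound 2 holds the lowest number of the two in this assay; the only neighbour is compound 1, and the step is large: a 100-fold lower number from compound 1 to compound 2 (2.00 log units; beyond the scatter).

Compound 3 `CCCOc1nc(N)c2nc(O)n(Cc3ccccc3)c2n1` is not yet measured. It differs from compound 2 at the same aromatic carbon: a group of 4 heavy atoms (3 carbon, 1 oxygen; no ring) in place of a group of 6 heavy atoms (4 carbon, 1 oxygen, 1 sulfur; no ring), on an aromatic carbon. Going by the values given here, the one measured step that bears on this position is a 100-fold lower number from compound 1 to compound 2 (2.00 log units; beyond the scatter), where replacing a single carbon with the six-atom, sulfur-bearing chain brought a large gain. Among the compounds with values here, compound 3 keeps a chain with one hydrogen-bond acceptor at that carbon but loses the sulfur; no measured pair shows this exchange directly, so the direction rests on the chain being retained. A modest loss is expected, near the edge of the scatter: a 3.0-fold higher number from compound 2 to compound 3 (0.48 log units; beyond the scatter). Compound 3 is therefore estimated at 0.03 uM in this assay, with a range from 0.005 uM to 0.3 uM.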

Compound 3, minimum effective concentration: 0.01 uM
For compound 3 the middle estimate is 3.0-fold (0.48 log units) above the measured one, within the range that was stated.
By their numbers in this assay, from the lowest: compounds 2 and 3 (each within the scatter of the next); then compound 1.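

In this assay, the low number at this aromatic carbon does not depend on sulfur: propoxy in place of methyl also gives a large step (a 100-fold lower number from compound 1 to compound 3 (2.00 log units; beyond the scatter)). Exchanging the sulfur-bearing group for the shorter propoxy group leaves the two compounds level (no change at the digits printed from compound 2 to compound 3 (within the scatter)), so the large step from the methyl compound is now seen with two different groups at this carbon. Nothing available explains why these two groups read alike.

Between methyl and these two chains, the compounds shown do not tell how much of the chain the low number needs, as ethoxy or methoxy at the same carbon would show. Also open, as far as these compounds go, is whether the position tolerates other kinds of group, such as a butylamino chain or a carboxylic acid, or a longer chain such as hexyloxy.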